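Swapping Trifluoromethyl for Chloro on the Aryl Ether

A few compounds are considered here, and "the series" means these few. Any claim that something is new, unique, unknown or untested is made for them only; others in the source may bear on it.

Measured so far:
- Compound 1, `COc1ccccc1N1CCN(C[C@H](O)COc2ccc(Cl)cc2)CC1`: 48.8%
- Compound 2, `O[C@H](COc1ccc(C(F)(F)F)cc1)CN1CCN(c2ccc(F)cc2)CC1`: 59.2%

Both compounds were tested in an assay on HEK293 cells for inhibition of Voltage-dependent T-type calcium channel subunit alpha-1G (Homo sapiens), read by patch clamp, tested at 10 uM; on this read-out lower numbers stand for less inhibition and higher numbers for more inhibition at the one concentration tested (going by the name of the read-out). Compound 2 stands highest of the two numbers; its nearest neighbour is compound 1, which gives 48.8%, a gap that lies beyond the usual scatter of this assay. Among the measured compounds shown here, compound 1 and compound 2 differ in more than one place, so no single-change step between them can be read off.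

The next compound, compound 3, `O[C@H](COc1ccc(Cl)cc1)CN1CCN(c2ccc(F)cc2)CC1`, is compound 2 with one change: chloro in place of trifluoromethyl on an aromatic carbon. For the measured compounds named here, no measured pair shows this exact change on its own, so there is nothing to copy directly. Compound 1 already carries a chloro on its aryl ether and sits lower than compound 2, but it also differs elsewhere, so it offers only a loose hint.

The expected step from compound 2 to compound 3 is a small decrease, a number 7.2 percentage points lower from compound 2 to compound 3 (within the scatter), which may well fall within the scatter. Compound 3 is therefore estimated at 52%, with a range from 36% to 66%.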

Compound 3, a percentage reported as inhibition, at one concentration (the size of the read-out at that concentration, not a potency): 28.3%
Compound 3: middle estimate off by 23.7 percentage points, on the high side; measured number outside the range, below it.
By their numbers in this assay, from the lowest: compound 3; then compound 1; then compound 2.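

In this assay the aryl ether position proves far from neutral: with the rest of the molecule unchanged, chloro in place of trifluoromethyl on an aromatic carbon, para to a large group, gives a number 30.9 percentage points lower from compound 2 to compound 3 (beyond the scatter) and replaces a group of 4 heavy atoms with a single atom. The other end of the molecule also matters, since with the chloro held constant, 4-fluorophenyl in place of 2-methoxyphenyl on an amine nitrogen in a ring gives a number 20.5 percentage points lower from compound 1 to compound 3 (beyond the scatter) and leaves compound 3 the lowest of the three. These two steps show how much each single change moves the number, but no measurement available here explains why either one does so.

The compounds shown leave open whether trifluoromethyl would raise the number in the same way on a molecule carrying the 2-methoxyphenyl group of compound 1, so it cannot be said whether the two changes act independently. They also leave open how a nitrile or a bromo on the same aromatic carbon would compare with chloro and trifluoromethyl.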